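This account rests on a few compounds, and the source may have more. Where it says the series, first, only, none or still open, it means among the compounds named here.

Two compounds have been run in an assay for inhibition of serine/threonine-protein kinase Sgk1 (Homo sapiens), with stated times of 30 min and 60 min, in the presence of a further agent that is not named here; a higher number here means a weaker inhibitor, a lower number a stronger inhibitor. Compound 1 `CCNC(=O)c1cc(-c2ccc(NS(=O)(=O)c3cccc(Cl)c3Cl)cc2)nc2[nH]ncc12` gives only a limit in that setting, < 1920 nM, as the limit of < 1920 nM in this assay, at which 1 of the 2 values shown sits, records. Among the compounds with values here, compound 2 `CCOc1nc(-c2ccc(NS(=O)(=O)c3cc(Cl)ccc3F)cc2)nc2[nH]nc(C)c12` gives the only plain number in this assay, 183 nM, and so stands alone as a measured point. Compound 3 `Cc1n[nH]c2nc(-c3ccc(NS(=O)(=O)c4cc(Cl)ccc4F)cc3)nc(OCCC(=O)N(C)C)c12` carries dimethylcarbamoyl in place of hydrogen on a saturated chain carbon, two bonds along the chain from an oxygen on an aromatic ring, placed on a saturated chain carbon, two bonds along the chain from an oxygen on an aromatic ring. Within the data shown here, no step between measured compounds is available, and the step from compound 2 to compound 3 is expected to stay within the scatter, a 1.1-fold lower number from compound 2 to compound 3 (0.06 log units; within the scatter). Compound 3 is therefore estimated at 160 nM, between 50 nM and 500 nM.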

Compound 3, half-maximal inhibitory concentration: 438 nM
Compound 3: the middle estimate sits 2.7-fold (0.44 log units) below what was measured; the range from low to high includes it.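

Changing ethoxy to 2-(dimethylcarbamoyl)ethoxy gives a 2.4-fold higher number from compound 2 to compound 3 (0.38 log units; beyond the scatter) in this assay. Within the data shown here, this is the first reading of a change at this position, and it shows a modest weakening, not a loss of inhibition, with the larger group still giving a measurable value. Nothing known about these compounds accounts for the step. Going by these compounds, it remains open whether the weakening follows the dimethylcarbamoyl group itself or the longer chain, and what an amine or a carboxylic acid in its place would give.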